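Amide to Ester on the Selenocyanate Chain

A few compounds are considered here, and "the series" means these few. Any claim that something is new, unique, unknown or untested is made for them only; others in the source may bear on it.

Measured compounds:
Compound 1, `COc1ccc(N(C)c2nc(C)nc3ccccc23)cc1C(=O)NCC[Se]C#N`, gives 179 nM.
Compound 2, `C[Se]c1ccc(N(C)c2nc(C)nc3ccccc23)cc1C`, gives 6 nM.
Compound 3, `Cc1nc(N(C)c2ccc([Se]C#N)c(F)c2)c2ccccc2n1`, gives 37 nM.

All three were tested in a functional assay on HepG2 cells (Homo sapiens) for inhibition, read by MTT assay, with a stated time of 48 h; on this read-out higher numbers stand for weaker inhibition and lower numbers for stronger inhibition. Among these numbers, compound 1 stands highest, meaning the weakest inhibition of the three. Its nearest neighbour is compound 3, whose number is lower by a margin that lies beyond the usual scatter, and compound 2 lies furthest from it, with the lowest number of the set, again well beyond the scatter.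

The next compound, compound 4, `COc1ccc(N(C)c2nc(C)nc3ccccc23)cc1C(=O)OCC[Se]C#N`, follows from compound 1 by a single change: a group of 6 heavy atoms (3 carbon, 1 nitrogen, 1 oxygen, 1 selenium; no ring) in place of a group of 6 heavy atoms (3 carbon, 2 nitrogen, 1 selenium; no ring), on a carbonyl carbon. For the measured compounds named here, no measured pair in this set shows a change of this kind, so there is no direct precedent to lean on. The remainder of the molecule is unchanged, and the group that enters matches the group that leaves in size. The expected step in this assay is therefore small, if anything towards a slightly higher number, and may well stay within the scatter; the step from compound 1 to compound 4 is estimated at a 1.5-fold higher number from compound 1 to compound 4 (0.16 log units; within the scatter). Compound 4 is expected to give about 260 nM, within a range from 90 nM to 750 nM.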

Compound 4, half-maximal inhibitory concentration: 890 nM
Compound 4: the middle estimate sits 3.4-fold (0.53 log units) below what was measured; the whole stated range lies below it.
By their numbers in this assay, from the lowest: compound 2; then compound 3; then compound 1; then compound 4.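

At the carbonyl carbon, replacing the amide link of the selenocyanate chain with an ester link is not a neutral exchange: in this assay it gives a 5.0-fold higher number from compound 1 to compound 4 (0.70 log units; beyond the scatter), which means weaker inhibition. For the compounds shown here, the earlier compounds offered no pair differing in one place, so this is the first readable step in the set, and it shows that this position responds to the exchange even though the group that enters matches the group that leaves in its count of 6 heavy atoms. The group that leaves has 1 hydrogen-bond donor and the group that enters has 0 hydrogen-bond donors, but no measurement at hand connects this or any other difference to the step.

The compounds shown leave open whether the step follows the amide hydrogen or the oxygen itself, since they do not include an amide with a methyl group on its nitrogen or a ketone with a methylene in place of the ester oxygen. They also leave open whether a longer chain between the carbonyl and the selenocyanate would keep the same difference between amide and ester.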